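Replacing 2,3-dimethoxyphenyl with 3-fluoro-4-hydroxyphenyl

The compounds below may be only part of what the source reports. "The series", "measured", "known", "first", "only" and "open" are said of these compounds alone.

In a functional assay on HepG2 cells (Homo sapiens) for antiproliferative activity, read by sulforhodamine B assay, with a stated time of 48 h (on this read-out higher numbers stand for weaker inhibition and lower numbers for stronger inhibition), compound 3 (`COc1cccc(C=C(C(=O)/C=C/c2cccc(OC)c2OC)C(=O)/C=C/c2cccc(OC)c2OC)c1OC`) gives 230 nM and compound 2 (`COc1cc(OC)c(C=C(C(=O)/C=C/c2cccc(OC)c2OC)C(=O)/C=C/c2cccc(OC)c2OC)c(OC)c1`) gives 300 nM and these two stand level, with a 1.3-fold lower number from compound 2 to compound 3 (0.12 log units; within the scatter) as the only gap between them. Compound 1 (`COc1cccc(/C=C/C(=O)C(=Cc2ccc(F)cc2)C(=O)/C=C/c2cccc(OC)c2OC)c1OC`) gives 580 nM and the measured comparisons with it are a 2.5-fold lower number from compound 1 to compound 3 (0.40 log units; beyond the scatter) and a 1.9-fold lower number from compound 1 to compound 2 (0.29 log units; within the scatter) in this series.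

Compound 4 (`COc1cccc(/C=C/C(=O)C(=Cc2ccc(O)c(F)c2)C(=O)/C=C/c2cccc(OC)c2OC)c1OC`) differs from compound 3 in one place: 3-fluoro-4-hydroxyphenyl in place of 2,3-dimethoxyphenyl on a double-bonded chain carbon bound to a double-bonded chain carbon on a double-bonded chain carbon bound to a double-bonded chain carbon. For the measured compounds named here, no measured compound carries 3-fluoro-4-hydroxyphenyl, so the data cannot settle what it does. The closest guide is compound 1, whose 4-fluorophenyl sits at the same place and which shows a 2.5-fold lower number from compound 1 to compound 3 (0.40 log units; beyond the scatter) in the reverse direction of this change. A modest rise in the number therefore seems likely, though with wide uncertainty.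

An estimated 2.0-fold higher number from compound 3 to compound 4 (0.29 log units; within the scatter) is expected in this assay for this change. For compound 4 the expected value is 450 nM with an estimated range from 170 nM to 1200 nM in all.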

Compound 4, half-maximal inhibitory concentration: 220 nM
Beside the measured number, compound 4's estimate is 2.0-fold (0.31 log units) above it; the range from low to high includes it.
By their numbers in this assay, from the lowest: compounds 4, 3, 2 and 1 (each within the scatter of the next, the first and the last beyond it).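

In this assay, the ring at this place can carry no methoxy group at all and still stand level with the rings that carry two or three (a 1.0-fold lower number from compound 3 to compound 4 (0.02 log units; within the scatter); a 1.4-fold lower number from compound 2 to compound 4 (0.13 log units; within the scatter)). Compound 1 also has no methoxy group on this ring, yet the hydroxyl-bearing ring gives a modest gain over it (a 2.6-fold lower number from compound 1 to compound 4 (0.42 log units; beyond the scatter)), so the lack of methoxy groups alone does not set compound 1 apart. Nothing available explains these differences.

The shown compounds cannot separate the part played by the hydroxyl from that of the fluorine, since no ring here carries a hydroxyl alone. As far as these compounds go, how a 4-aminophenyl ring or a ring bearing a carboxylic acid would behave at this place also remains open.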